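The source may hold more compounds than are shown below. What is called first, only, known or untested is meant among the compounds shown, and "the series" means these compounds.

The account begins with compound 1, `CCCCCCCCCCCCOC(=O)/C(C#N)=C/c1ccc(O)c(O)c1`, which in a functional assay on the whole organism (strain CD1) for inhibition, with Mus musculus as the target, with stated times of 15 min and 20 min, at a dose of 10 mg/kg by the subcutaneous route (a higher number here means more inhibition at the dose given (going by the name of the read-out), a lower number less inhibition), gives 45.2%. Going by the values given here, the only other measured member of the set, compound 2, `CC(C)(C)OC(=O)/C(C#N)=C/c1ccoc1`, gives 81.8% in this assay. Of the two numbers, compound 1 stands lowest, and compound 2 lies higher by a margin that goes beyond the usual scatter of the test. Since compound 1 and compound 2 differ in more than one place, that gap tells nothing about any single change on its own.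

The step under study leads from compound 1 to compound 3, `CCCCCCCCCCCCOC(=O)/C(C#N)=C/c1cc2ccccc2[nH]1`. The change is 1H-indol-2-yl in place of 3,4-dihydroxyphenyl on a double-bonded chain carbon bound to a double-bonded chain carbon, while the rest of the molecule stays as in compound 1. Among the compounds with values here, no step between two measured compounds is known for a change of this kind, so the expectation rests on compound 1 alone. The step is expected to be small in relation to the scatter, with no clear direction, as given by a number 4.8 percentage points higher from compound 1 to compound 3 (within the scatter). Compound 3 is accordingly expected to give about 50% in this assay, within an estimated range from 20% to 80%.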

Compound 3, a percentage reported as inhibition, in the whole organism at one dose (the size of the read-out at that dose, not a potency): 54.1%
For compound 3 the middle estimate is 4.1 percentage points below the measured one; the measured number falls inside the stated range.
By their numbers in this assay, from the lowest: compounds 1 and 3 (each within the scatter of the next); then compound 2.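

Going by these compounds alone, exchanging 3,4-dihydroxyphenyl for 1H-indol-2-yl on a double-bonded chain carbon bound to a double-bonded chain carbon gives, in this assay, a number 8.9 percentage points higher from compound 1 to compound 3 (within the scatter), and this is the first reading of a single change in the set. The step shows that this place accepts a marked change of group without a difference that can be told from the scatter: 3,4-dihydroxyphenyl, with 2 hydrogen-bond donors and 2 hydrogen-bond acceptors, gives way to 1H-indol-2-yl, with 1 hydrogen-bond donor and 0 hydrogen-bond acceptors, while the rest of the molecule stays the same. Nothing available here accounts for the two groups reading alike.

The compounds shown leave open whether a group carrying an amine or a carboxylic acid at this place would also stay within the scatter of compound 1, and what a single change in the ester chain, such as a shorter chain, would do while this place stays fixed. They also leave open how this step would look at other doses, since the read-out reports the size of the effect at one dose and not a potency.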